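Cytotoxicity notes: phenyl amide to pyrrolidinylethyl amide

The source may report more compounds than this note shows. Statements on the series, on what has been measured and on what is new or still open speak of the compounds shown alone.

The series shares the core seen in compound 1 `COCCNC(=O)c1n[nH]cc1NC(=O)c1c(OC)cccc1OC`, compound 2 `COc1cccc(OC)c1C(=O)Nc1c[nH]nc1C(=O)NCCCOC(C)C` and compound 3 `COc1cccc(OC)c1C(=O)Nc1c[nH]nc1C(=O)Nc1ccccc1`. In an ADME assay on MRC5 cells (Homo sapiens) for inhibition, with a stated time of 72 h (on this read-out lower numbers stand for an effect already at smaller amounts and higher numbers for an effect only at larger amounts of compound), compound 1 gives only a limit, > 50000 nM. In this assay compound 2 likewise reaches only a limit, > 50000 nM. Compound 3 stands at a limit as well, > 50000 nM in this assay. The steps a step that the two limits leave unreadable from compound 1 to compound 2, a step that the two limits leave unreadable from compound 1 to compound 3 and a step that the two limits leave unreadable from compound 2 to compound 3 therefore cannot be sized, because of the limit of > 50000 nM in this assay, at which 3 of the 3 values shown sit. Compound 4 `COc1cccc(OC)c1C(=O)Nc1c[nH]nc1C(=O)NCCN1CCCC1` differs from compound 3 in one place: 2-(pyrrolidin-1-yl)ethyl in place of phenyl on an amide-type nitrogen. Among the compounds with values here, none of the measured steps can be read, so no direction beyond the scatter follows for this change; the three measured compounds all sit at the limit whether the amide nitrogen carries 2-methoxyethyl, 3-isopropoxypropyl or phenyl. Compound 4 is accordingly expected to remain at the limit, with the step of a number no higher from compound 3 to compound 4 (the limit leaves the size open) expected to carry no readable size. The estimate for compound 4 in this assay is 50000 nM, within 20000 nM to 100000 nM.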

Compound 4, half-maximal effective concentration: > 50000 nM
Compound 4 ended at the assay's limit (the forecaster's own chance of this, stated with the estimate: 80%); the middle value lies on the limit itself.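

In this assay compound 4 gives only a limit, > 50000 nM. Its steps from compound 1, compound 2 and compound 3 cannot be read, because the values offer no size to compare: the limit of > 50000 nM in this assay, at which 4 of the 4 values shown sit. The compounds shown leave open whether the group on the amide nitrogen changes this read-out at all.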